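The source may report more compounds than this note shows. Statements on the series, on what has been measured and on what is new or still open speak of the compounds shown alone.

Measured so far in an ADME assay on HepG2 cells (Homo sapiens) for cytotoxicity, read by MTT assay, with a stated time of 24 h; on this read-out higher numbers stand for lower toxicity in this test and lower numbers for higher toxicity in this test:

Compound 1, `COc1cccc(N2CCN(Cc3ccc([N+](=O)[O-])o3)CC2)c1`. In this assay compound 1 gives > 63000 nM, which is a limit of the assay and not a number.
Compound 2, `O=[N+]([O-])c1ccc(CN2CCN(S(=O)(=O)c3ccccc3)CC2)o1`. In this assay compound 2 gives > 56000 nM, likewise a limit of the assay and not a number.

Where compound 2 stands: only a limit is known for it in this assay, and the one further value shown is a limit too. Going by the values given here, the two values sit at the limit of > 56000 nM in this assay, at which 1 of the 2 values shown sits, and at the limit of > 63000 nM in this assay, at which 1 of the 2 values shown sits, so no step between measured compounds can be counted, and no direction of change within the pair can be read from them.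

Compound 3, `O=[N+]([O-])c1ccc(S(=O)(=O)N2CCN(Cc3ccc([N+](=O)[O-])o3)CC2)cc1`, is not yet measured in this assay. It differs from compound 2 in one place: nitro in place of hydrogen on an aromatic carbon. With both measured values resting at limits, nothing in the numbers points to a shift in either direction, and the step expected from compound 2 to compound 3 in this assay is a step that the limit leaves unreadable from compound 2 to compound 3, none beyond the scatter. Compound 3 is expected to come in at about 60000 nM, within 30000 nM to 120000 nM, most likely again reported only as a limit.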

Compound 3, half-maximal cytotoxic concentration: > 50000 nM
Compound 3: a limit, no number; the forecaster's own chance of this, stated with the estimate: 80%; the middle value is on the limit's open side.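

Compound 2 and compound 3 both rest at limits in this assay, so no step can be read between them for nitro in place of hydrogen on an aromatic carbon. The compounds shown leave open where any of them would give an actual number in this assay, and whether going from phenyl to 4-nitrophenyl shifts that number at all.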